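This account rests on a few compounds, and the source may have more. Where it says the series, first, only, none or still open, it means among the compounds named here.

Measured compounds:
Compound 1, `COc1ccc(/C=C2\SC(=O)N(Cc3ccc(C)cc3)C2=O)c(OC)c1`, gives 21.8% in a functional assay on the whole organism (plasma) with Mus musculus as the target, with a stated time of 15 days, at a dose of 10 mg/kg by the oral route; a higher number here means a stronger effect of the compound at the dose given, a lower number a weaker effect.
Compound 2, `Cc1ccc(CN2C(=O)S/C(=C\c3ccccc3Cl)C2=O)cc1`, gives 19.2% in this assay.
Compound 3, `Cc1ccc(CN2C(=O)S/C(=C\c3ccc(O)cc3)C2=O)cc1`, gives 19.9% in this assay.

Compound 2 stands at the low end of these three numbers, yet the three lie close together: the nearest is compound 3, reached by a step of a number 0.7 percentage points higher from compound 2 to compound 3 (within the scatter) that is within the scatter, and the furthest is compound 1, whose gap to compound 2 is also within the scatter. In short, the three measured compounds cannot be told apart in this assay.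

Compound 4, `Cc1ccc(CN2C(=O)S/C(=C\OCc3ccccc3)C2=O)cc1`, has not yet been measured. It differs from compound 2 in one place: benzyloxy in place of 2-chlorophenyl on a double-bonded chain carbon bound to a double-bonded ring carbon. Among the compounds with values here, only one measured step touches the same place, the one from compound 2 to compound 3, in which the 2-chlorophenyl gave way to a 4-hydroxyphenyl; that step was a number 0.7 percentage points higher from compound 2 to compound 3 (within the scatter), within the scatter. Within the data shown here, a benzyloxy is a different group again, and no measured pair shows what a benzyloxy does here, but the one comparison that exists suggests the group at this place makes little difference. Compound 4 is therefore expected to show a step of a number 0.3 percentage points higher from compound 2 to compound 4 (within the scatter) in this assay, nothing beyond the scatter. The estimate for compound 4 is 19.5%, in a range from 10% to 29%.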

Compound 4, a percentage reported as activity, at one dose (the size of the read-out at that dose, not a potency): 9.37%
Compound 4: middle estimate off by 10.1 percentage points, on the high side; the measured number lies below the stated range.
By their numbers in this assay, from the lowest: compounds 4, 2, 3 and 1 (each within the scatter of the next, the first and the last beyond it).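

Benzyloxy in place of 4-hydroxyphenyl on a double-bonded chain carbon bound to a double-bonded ring carbon gives a number 10.5 percentage points lower from compound 3 to compound 4 (beyond the scatter) in this assay, the first step at this place to clear the usual scatter, although only modestly. Against 2-chlorophenyl the same group gives a number 9.8 percentage points lower from compound 2 to compound 4 (within the scatter), so the change is secure against only one of the two compounds it can be compared with, and the earlier impression that the group here makes little difference is weakened rather than overturned. Nothing measured in this set explains why the number falls with benzyloxy.

The compounds shown do not separate the oxygen of the benzyloxy from its ring, and a benzylamino group or a plain longer carbon chain at this place would be needed to tell whether the oxygen or the overall shape of the group goes with the lower number. On these data alone, a carboxylic acid or an amine on the ring at this place also remains untested in this set, as does any dose other than the single one used here, so how the effect changes with dose stays unknown.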